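Compound 2 gains a 3-bromo-4-fluorophenyl group

The source may hold more compounds than are shown below. What is called first, only, known or untested is meant among the compounds shown, and "the series" means these compounds.

In an ADME assay on Vero cells (Chlorocebus sabaeus) for cytotoxicity, read by resazurin assay, with a stated time of 72 h (on this read-out lower numbers stand for stronger inhibition and higher numbers for weaker inhibition), compound 2 `O=C(CCN1CCN(c2ccc(C(F)(F)F)cc2)CC1)c1ccccc1` gives 15700 nM and sits within the scatter of compound 1 `O=C(CCN1CCN(c2ccc(F)cc2)CC1)c1ccccc1` at 13400 nM in the same measurement. Compound 3 `O=C(CCN1CCN(c2ccc(Cl)cc2)CC1)c1ccc(Br)cc1` reads higher at 52100 nM and that gap lies beyond the scatter. Compound 4 `O=C(CCN1CCN(c2ccc(C(F)(F)F)cc2)CC1)c1ccc(F)c(Br)c1` carries 3-bromo-4-fluorophenyl in place of phenyl on a carbonyl carbon. Among the measured compounds shown here, the only measured single-place step (a 1.2-fold higher number from compound 1 to compound 2 (0.07 log units; within the scatter)) put trifluoromethyl in place of fluoro on an aromatic carbon and stayed within the scatter. For the measured compounds named here, no measured step covers the change at the carbonyl carbon, so no shift beyond the scatter is expected. The expected step is small (a 1.3-fold higher number from compound 2 to compound 4 (0.11 log units; within the scatter)) and uncertain in direction. Compound 4 is estimated at 20000 nM with an expected range from 8000 nM to 48000 nM in this measurement.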

Compound 4, half-maximal inhibitory concentration: 66800 nM
The estimate for compound 4 lay 3.3-fold (0.52 log units) below the measured number, outside the stated range (above it).
By their numbers in this assay, from the lowest: compounds 1 and 2 (each within the scatter of the next); then compounds 3 and 4 (each within the scatter of the next).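

In this assay, the aryl group on the carbonyl carbon proves able to move the number: 3-bromo-4-fluorophenyl in place of phenyl gives a 4.3-fold higher number from compound 2 to compound 4 (0.63 log units; beyond the scatter), whereas the earlier change on an aromatic carbon, a 1.2-fold higher number from compound 1 to compound 2 (0.07 log units; within the scatter), did not. No evidence is available to explain this shift. The compounds shown leave open whether the bromine or the fluorine carries the step, since both entered together, and whether a nitrile or an amine on that phenyl would shift the number in the same way.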